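A Chloro-to-Methoxy Swap Close to the Assay Limit

A few compounds are considered here, and "the series" means these few. Any claim that something is new, unique, unknown or untested is made for them only; others in the source may bear on it.

In a functional assay on HeLa cells (Homo sapiens) for inhibition, read by MTT assay, with a stated time of 48 h (on this read-out higher numbers stand for weaker inhibition of growth and lower numbers for stronger inhibition of growth), compound 1 `Cn1cc(C2CC(c3ccccc3)=NN2C(=O)c2cccnc2)c2ccccc21` gives > 10000 nM, which is a limit of the assay and not a number. Among the measured compounds shown here, compound 2 `Cn1cc(C2CC(c3ccccc3)=NN2C(=O)c2ccc(Cl)nc2)c2ccccc21` gives 8310 nM, the only exact number so far. Putting chloro in place of hydrogen on an aromatic carbon produced an at least 1.2-fold lower number from compound 1 to compound 2 (0.08 log units; that floor lies within the scatter). For the measured compounds named here, this is the only measured step that bears on the next change, and it offers a weak guide, since it starts from a limit and involves no methoxy group.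

Compound 3 `COc1ccc(C(=O)N2N=C(c3ccccc3)CC2c2cn(C)c3ccccc23)cn1` has not yet been measured. It differs from compound 2 by methoxy in place of chloro on an aromatic carbon, with methoxy in place of chloro on an aromatic carbon, next to the ring nitrogen. With so little to go on, no step beyond the scatter is expected in this assay, in either direction. The estimated step is a 1.1-fold higher number from compound 2 to compound 3 (0.03 log units; within the scatter). Compound 3 could also prove to reach the limit of the assay and return no exact number. Compound 3 is expected to give about 9000 nM, with an estimated range from 4000 nM to 18000 nM.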

Compound 3, concentration for 50% growth inhibition: 3980 nM
For compound 3 the middle estimate is 2.3-fold (0.35 log units) above the measured one; the measured number lies below the stated range.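

In this assay, putting methoxy in place of chloro gave a 2.1-fold lower number from compound 2 to compound 3 (0.32 log units; beyond the scatter). This shows that the group on this carbon of the pyridine ring can shift the growth read-out by more than the usual scatter, which the chloro step alone could not show. Methoxy in place of hydrogen gave an at least 2.5-fold lower number from compound 1 to compound 3 (0.40 log units; beyond the scatter), so unlike the chloro step, this comparison with the compound that has no group at this position also clears the scatter. That step is only a floor, because compound 1 gives a limit of the assay and not a number: the limit of > 10000 nM in this assay, at which 1 of the 3 values shown sits.

From the compounds shown here alone, with only these compounds, it remains open whether the oxygen or the added carbon of the methoxy group matters more, and what a hydroxy group, an amine or a longer chain such as ethoxy would do on this same carbon. Going by these compounds, all three results also come from a single cell line and a single read-out, so it remains unknown whether the step from chloro to methoxy would hold in other cells.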